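Methyl to ethyl on the shared core: expectation for compound 3

The source may report more compounds than this note shows. Statements on the series, on what has been measured and on what is new or still open speak of the compounds shown alone.

Measured compounds:
compound 1 `Cc1nc(C#Cc2cccc(OC(F)(F)F)c2)cs1` — 266 nM
compound 2 `Cc1nc(C#Cc2cccnc2)c(C)s1` — 698 nM

In a functional assay on CHO cells for agonist activity at metabotropic glutamate receptor 5 (Homo sapiens), read by inositol phosphate accumulation (on this read-out lower numbers stand for stronger inhibition and higher numbers for weaker inhibition), compound 1 gives 266 nM and compound 2 gives 698 nM. Compound 2 stands with the highest number of the two; the gap to compound 1 lies beyond the scatter. The two compounds differ in more than one place, so their pair shows only what the two values are, and no single step can be read from them.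

Compound 3 `CCc1sc(C)nc1C#Cc1cccnc1` is not yet measured in this assay. Against compound 2 the change is methyl in place of hydrogen on a saturated chain carbon bound to an aromatic carbon, read one bond further out as methyl to ethyl. Within the data shown here, no pair of measured compounds shares this change, so there is no comparable step to lean on. The expectation is a step from compound 2 to compound 3 of a 1.2-fold lower number from compound 2 to compound 3 (0.07 log units; within the scatter), in no settled direction and not beyond the scatter. On that basis compound 3 is estimated at 600 nM, with a range from 250 nM to 1500 nM.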

Compound 3, half-maximal inhibitory concentration: 1240 nM
Compound 3: the middle estimate sits 2.1-fold (0.32 log units) below what was measured; the range from low to high includes it.
By their numbers in this assay, from the lowest: compound 1; then compounds 2 and 3 (each within the scatter of the next).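

In this assay, among these compounds, methyl in place of hydrogen on a saturated chain carbon bound to an aromatic carbon, read one bond further out as methyl to ethyl, gives a 1.8-fold higher number from compound 2 to compound 3 (0.25 log units; within the scatter), the first step that can be read at a single place. At this position, the change from methyl to ethyl therefore leaves compound 2 and compound 3 within the scatter of each other, so this one added carbon produces no separation on this read-out, though a single pair cannot fix a trend for the position. No measurement shown speaks to what lies behind this step.

Steps between compound 1 and the other two compounds cannot be read, as each of those pairs differs in more than one place. Open at this same position is whether a longer chain such as propyl, an amine or a carboxylic acid would give a step beyond the scatter, and in which direction.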